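The source may hold more compounds than are shown below. What is called first, only, known or untested is meant among the compounds shown, and "the series" means these compounds.

Measured so far:
compound 1 `O=S(=O)(Nc1ccc(-c2nc3ccccc3o2)cc1)c1cccc(O)c1` — > 100000 nM, a limit of the assay.
compound 2 `O=S(=O)(Nc1ccc(-c2nc3ccccc3o2)cc1)c1cccs1` — > 100000 nM, a limit of the assay.
compound 3 `O=S(=O)(Nc1ccc2oc(-c3ccccc3)nc2c1)c1cccc(O)c1` — > 100000 nM, a limit of the assay.

All three values come from an ADME assay on HEK293 cells (Homo sapiens) for cytotoxicity, read by resazurin assay, with a stated time of 48 h; a lower number here means that less compound is tolerated, a higher number that more compound is tolerated. Compound 2 differs from compound 1 by thiophen-2-yl in place of 3-hydroxyphenyl on a sulfonyl sulfur. The step that the two limits leave unreadable from compound 1 to compound 2 cannot be read, as both ends sit at the limit. Compound 3 has the same atoms as compound 1 joined differently; the difference between the two cores is not broken down here.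

Compound 4 `O=S(=O)(Nc1ccc2oc(-c3ccccc3)nc2c1)c1cccs1` is not yet measured in this assay. It differs from compound 3 by thiophen-2-yl in place of 3-hydroxyphenyl on a sulfonyl sulfur, the same change as from compound 1 to compound 2, at a place described in the same words. The only pattern seen is the limit of > 100000 nM in this assay, at which 3 of the 3 values shown sit, with no exception among the three.

On that basis compound 4 is expected to sit at the same limit, so the step that the limit leaves unreadable from compound 3 to compound 4 is estimated as flat. The estimate for compound 4 is 150000 nM, with a range from 60000 nM to 400000 nM, resting on compound 3 giving > 100000 nM and on the unreadable step from compound 1 to compound 2.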

Compound 4, half-maximal cytotoxic concentration: 97000 nM
The estimate for compound 4 lay 1.5-fold (0.19 log units) above the measured number; the range from low to high includes it.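

In this assay, thiophen-2-yl in place of 3-hydroxyphenyl on a sulfonyl sulfur gives an at least 1.0-fold lower number from compound 3 to compound 4 (0.01 log units; that floor lies within the scatter), so on the core of compound 3 the change produces no shift that can be told from the scatter. On the core of compound 1 the same change cannot be read, as both ends of that step are limits, so the two cores cannot be compared and no size of effect is shown to carry from one to the other. Within the data shown here, the series offers only one number to work with, and the rest of the set stays capped: the limit of > 100000 nM in this assay, at which 3 of the 4 values shown sit.

Still open, on these data alone, is whether any other group on a sulfonyl sulfur, such as an aminomethylphenyl, a carboxylic acid-bearing phenyl or a longer alkyl chain, would give a number clearly apart from those of compound 3 and compound 4. Also open, as far as these compounds go, is whether a change that can be read on one core would repeat on the other.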